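Swapping a furan for a cyanopyridine on the shared core

This account rests on a few compounds, and the source may have more. Where it says the series, first, only, none or still open, it means among the compounds named here.

Within the data shown here, compound 1 `CC(C)c1ccc(-c2nc(N)c3cc(Cc4ccccc4)sc3n2)o1` is the only compound here with a full number: in a functional assay on CHO-K1 cells for antagonist activity at adenosine receptor A1 (Homo sapiens), read by a beta-galactosidase reporter and cAMP accumulation, with stated times of 15 min and 6 h (on this read-out lower numbers stand for stronger inhibition and higher numbers for weaker inhibition), compound 1 gives 283 nM. Compound 2 `Cc1csc(-c2nc(N)c3cc(C4(c5ccccc5)CC4)sc3n2)n1` reaches only a limit of the assay, (the limit of > 610 nM in this assay, at which 1 of the 3 values shown sits), so in this assay compound 2 shows > 610 nM. Compound 3 `Nc1nc(-c2cccc(C(F)(F)F)c2)nc2sc(Cc3ccccc3)cc12` likewise reaches only a limit, (the limit of > 1000 nM in this assay, at which 1 of the 3 values shown sits), and in this assay compound 3 shows > 1000 nM. Compound 4 `N#Cc1cccc(-c2nc(N)c3cc(Cc4ccccc4)sc3n2)n1` is not yet measured; it differs from compound 1 in one place: 6-cyanopyridin-2-yl in place of 5-isopropylfuran-2-yl on an aromatic carbon. Among the measured compounds shown here, with no measured step between two compounds to lean on, the size of the expected change is uncertain, and a loss beyond the usual scatter is expected, a 2.5-fold higher number from compound 1 to compound 4 (0.39 log units; beyond the scatter). Compound 4 is therefore estimated at 700 nM, within 150 nM to 3000 nM.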

Compound 4, inhibition constant: > 1000 nM
Compound 4 gave a limit, no number; the forecaster's own chance of this, stated with the estimate: 40%; middle value at least 1.4-fold (0.15 log units) from the limit.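

Among these compounds, on the shared core, 6-cyanopyridin-2-yl in place of 5-isopropylfuran-2-yl gives an at least 3.5-fold higher number from compound 1 to compound 4 (0.54 log units; beyond the scatter), the first measured step in this set. Both groups have the same count of heavy atoms, so keeping that count at this position does not keep the read-out in this assay. Compound 4 stands at a limit of the assay, not at a number: the limit of > 1000 nM in this assay, at which 2 of the 4 values shown sit.

As far as these compounds go, it stays open whether the change of ring or the nitrile accounts for the step. A plain pyridin-2-yl group or a plain furan-2-yl group at this position would help to separate the two.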